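A few compounds are considered here, and "the series" means these few. Any claim that something is new, unique, unknown or untested is made for them only; others in the source may bear on it.

Of the compounds shown here, three have been tested in an assay on microsomes from liver for inhibition of acyl-CoA desaturase 1 (Rattus norvegicus); on this read-out higher numbers stand for weaker inhibition and lower numbers for stronger inhibition. Compound 1 `FC(F)(F)c1ccc(OC2CCN(c3ccc(-n4ccnc4)nn3)CC2)cc1` carries a phenyl ring bearing a trifluoromethyl group on the oxygen attached to the saturated ring carbon, and compound 1 gives 371 nM. Compound 2 `COc1ccccc1OC1CCN(c2ccc(-n3ccnc3)nn2)CC1` carries a 2-methoxyphenyl group at that oxygen, and in this assay compound 2 gives 543 nM. Compound 3 `CC(C)(C)c1nnc(-c2ccc(N3CCC(Oc4ccccc4C(F)(F)F)CC3)nn2)o1` has a different core together with another trifluoromethyl-bearing phenyl ring, and in this assay compound 3 gives 980 nM. Among these three numbers compound 2 stands second highest. Its value lies close to that of compound 1, and the gap between the two falls within the usual scatter of the measurement, so they cannot be told apart. The gap to compound 3 also stays within that scatter.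

Compound 4 `Brc1cccc(OC2CCN(c3ccc(-n4ccnc4)nn3)CC2)c1` has not been measured. It differs from compound 2 in one place: 3-bromophenyl in place of 2-methoxyphenyl on an oxygen on a saturated carbon

Among the compounds with values here, no measured pair shows what such a swap does. Compound 1 and compound 2, which differ only in the group on that oxygen, sit within the scatter of each other, which supports only a modest change. The step expected in this assay is a 1.3-fold lower number from compound 2 to compound 4 (0.11 log units; within the scatter), and it may well not exceed the scatter. Compound 4 is therefore estimated at 420 nM, within a range from 150 nM to 1200 nM.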

Compound 4, half-maximal inhibitory concentration: 23 nM
Compound 4: the middle estimate sits 18-fold (1.26 log units) above what was measured, outside the stated range (below it).
By their numbers in this assay, from the lowest: compound 4; then compounds 1, 2 and 3 (each within the scatter of the next, the first and the last beyond it).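

In this assay, within the data shown here, the group on an oxygen on a saturated carbon turns out to matter far more than the earlier compounds could show: putting 3-bromophenyl in place of 2-methoxyphenyl gives a 24-fold lower number from compound 2 to compound 4 (1.37 log units; beyond the scatter), a clear gain in inhibition. Both groups hold one six-membered aromatic ring of carbon only, so a change in what sits on that ring, and where it sits, is enough to produce a large step in this series. Nothing shown here bears on why the step is so large, so the reason for it remains unknown.

The compounds shown do not separate the effect of the bromine from the effect of its place on the ring, a question that a comparison of 3-bromophenyl with 2-bromophenyl and 3-methoxyphenyl on the same oxygen would address. On these data alone, it also remains open whether 3-bromophenyl would bring a similar step on the core of compound 3, or whether this result holds only for the core shared by compound 2 and compound 4.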